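The source may hold more compounds than are shown below. What is called first, only, known or untested is meant among the compounds shown, and "the series" means these compounds.

Measured so far in a functional assay on DU-145 cells (Homo sapiens) for inhibition, read by MTT assay, with a stated time of 24 h; on this read-out higher numbers stand for weaker inhibition and lower numbers for stronger inhibition:
compound 1 `CCOC(=O)C1=Cc2ccccc2OC1(OCc1cn(-c2cccc(OC)c2)nn1)C(F)(F)F` gives > 150000 nM, which is a limit of the assay and not a number.
compound 2 `CCOC(=O)C1=Cc2ccccc2OC1(OCc1cn(CC(=O)NC2CCCCC2)nn1)C(F)(F)F` gives 10200 nM.
compound 3 `CCCCCCCCn1cc(COC2(C(F)(F)F)Oc3ccccc3C=C2C(=O)OCC)nn1` gives > 150000 nM, again a limit of the assay and not a number.

Compound 3 therefore has no number of its own in this assay; it sits at the limit of > 150000 nM in this assay, at which 2 of the 3 values shown sit, together with compound 1, while compound 2 alone gives a readable value.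

The next compound, compound 4 `CCOC(=O)C1=Cc2ccccc2OC1(OCc1cn(CC(=O)Nc2ccc(OC)cc2)nn1)C(F)(F)F`, differs from compound 3 in one place: (4-methoxyphenyl)carbamoyl in place of heptyl on a saturated chain carbon bound to an aromatic nitrogen. The closest measured step runs the other way: an at least 14-fold higher number from compound 2 to compound 3 (1.16 log units; beyond the scatter), a large loss when the cyclohexylcarbamoyl group gave way to heptyl. The step that the two limits leave unreadable from compound 1 to compound 3 is unreadable because both ends are limits, and an at least 14-fold lower number from compound 1 to compound 2 (1.16 log units; beyond the scatter) shows that a carbamoylmethyl chain on the aromatic nitrogen reads far better than 3-methoxyphenyl. Compound 4 brings back a carbamoyl group, with an aromatic ring in place of the cyclohexyl, so a return toward the range of compound 2 is expected, that is a large downward step an at least 10-fold lower number from compound 3 to compound 4 (1.00 log units; beyond the scatter). Compound 4 is thus estimated at 15000 nM, with a range from 3500 nM to 150000 nM, the upper end allowing that only a limit is reported.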

Compound 4, half-maximal inhibitory concentration: 32700 nM
Beside the measured number, compound 4's estimate is 2.2-fold (0.34 log units) below it; measured number inside the range.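

In this assay, a second amide on the chain bound to the aromatic nitrogen again gives a readable value, now with an aromatic ring on the amide-type nitrogen: the record shows an at least 4.5-fold lower number from compound 3 to compound 4 (0.66 log units; beyond the scatter) and an at least 4.5-fold lower number from compound 1 to compound 4 (0.66 log units; beyond the scatter), each starting from a limit of the assay and not from a number. The only step among these with a number at both ends is a 3.2-fold higher number from compound 2 to compound 4 (0.51 log units; beyond the scatter), so the group on the amide-type nitrogen changes the reading, with 4-methoxyphenyl giving the higher number and cyclohexyl the lower. An aromatic ring as such does not keep a compound at the limit, since compound 4 carries one and gives a number, while compound 1, which also carries one, stays with compound 3 at the limit: the limit of > 150000 nM in this assay, at which 2 of the 4 values shown sit.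

Open, from the compounds shown here alone, is whether the amide alone carries the reading, which a primary amide, a carboxylic acid or an amine at the end of the same short chain would test. Also open, going by these compounds, is how the reading follows the group on the amide-type nitrogen, for instance with plain phenyl, 3-methoxyphenyl or a smaller ring such as cyclopentyl.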